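The compounds below may be only part of what the source reports. "The series", "measured", "known", "first", "only" and "open" are said of these compounds alone.

Three compounds built on a shared core, differing only in the group attached to the carbonyl carbon, have been measured in a functional assay on B16-F10 cells (Mus musculus) for antiproliferative activity, read by MTT assay, with a stated time of 48 h; a higher number here means a weaker inhibitor, a lower number a stronger inhibitor. Compound 1 `CCCCCCCCCCCCOc1ccc(C(=O)/C=C/c2c(/C=C/c3ccc(OC)cc3)cc(OC)cc2OC)cc1` gives 12.7 ug/mL. Compound 2 `CCCCCCOc1ccc(C(=O)/C=C/c2c(/C=C/c3ccc(OC)cc3)cc(OC)cc2OC)cc1` gives 10.4 ug/mL, a change of a 1.2-fold lower number from compound 1 to compound 2 (0.09 log units; within the scatter). Compound 3 `COc1ccc(/C=C/c2cc(OC)cc(OC)c2/C=C/C(=O)c2ccc(Br)cc2)cc1` gives 6.5 ug/mL, a change of a 1.6-fold lower number from compound 2 to compound 3 (0.20 log units; within the scatter). Compound 3 therefore holds the lowest of the three numbers, but its gaps to compound 2 and to compound 1 both lie within the scatter, so no ordering can be read from them.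

Compound 4 `COc1ccc(/C=C/c2cc(OC)cc(OC)c2/C=C/C(=O)c2ccc(C)c(C)c2)cc1` has not yet been measured. Its difference from compound 3 is 3,4-dimethylphenyl in place of 4-bromophenyl on a carbonyl carbon. Among the compounds with values here, no measured step replaces a bromo with methyl groups, so the nearest guidance comes from the two steps already seen at this same position, a 1.2-fold lower number from compound 1 to compound 2 (0.09 log units; within the scatter) and a 1.6-fold lower number from compound 2 to compound 3 (0.20 log units; within the scatter), both of which stayed within the scatter despite sizeable changes to the group on the carbonyl carbon. The step from compound 3 to compound 4 is therefore expected to be small, a 1.2-fold higher number from compound 3 to compound 4 (0.06 log units; within the scatter), with no clear direction. Compound 4 is estimated at 7.5 ug/mL, expected to fall between 3.5 ug/mL and 16 ug/mL.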

Compound 4, half-maximal inhibitory concentration: 1.4 ug/mL
Estimate against measurement, compound 4: 5.4-fold (0.73 log units) above; measured number below the stated range.
By their numbers in this assay, from the lowest: compound 4; then compounds 3, 2 and 1 (each within the scatter of the next).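

The group on the carbonyl carbon can shift the number in this assay beyond the scatter: replacing 4-bromophenyl with 3,4-dimethylphenyl gives a 4.6-fold lower number from compound 3 to compound 4 (0.67 log units; beyond the scatter), the only step among those shown at this position to do so. The two groups look alike in what can be counted, since each has one six-membered aromatic ring of carbon only and neither has a hydrogen-bond donor or acceptor, so the small earlier steps did not mean that every change here is tolerated. Nothing available explains this step.

From the compounds shown here alone, whether this drop needs both methyl groups remains open, and a 4-methylphenyl or 3-methylphenyl group would address that. The compounds shown also leave unknown how an amine or a carboxylic acid on this ring would behave.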